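One more carbon on the sulfur-linked chain

The compounds below may be only part of what the source reports. "The series", "measured", "known", "first", "only" and "open" are said of these compounds alone.

Compound 1, `CCCOc1nc(C(C)(C)C)ccc1CNC(=O)C(C)c1ccc(NS(C)(=O)=O)c(F)c1`: 1.7 nM
Compound 2, `CCCCOc1nc(C(C)(C)C)ccc1CNC(=O)C(C)c1ccc(NS(C)(=O)=O)c(F)c1`: 0.9 nM
Compound 3, `CCCCSc1nc(C(C)(C)C)ccc1CNC(=O)C(C)c1ccc(NS(C)(=O)=O)c(F)c1`: 3.2 nM

All three were measured in an assay on cells for antagonist activity at transient receptor potential cation channel subfamily V member 1 (Homo sapiens), read by FLIPR and calcium flux, with a stated time of 6 min; a lower number here means a stronger inhibitor, a higher number a weaker inhibitor. Compound 1 and compound 2 share one core and differ by methyl in place of hydrogen on a saturated chain carbon, three bonds along the chain from an oxygen on an aromatic ring; this change gave a 1.9-fold lower number from compound 1 to compound 2 (0.28 log units; within the scatter). Compound 3 carries a different core, differing from compound 1 by butylsulfanyl in place of propoxy on an aromatic carbon, which gave a 1.9-fold higher number from compound 1 to compound 3 (0.27 log units; within the scatter). Against compound 2 the step was a 3.6-fold higher number from compound 2 to compound 3 (0.55 log units; beyond the scatter).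

Compound 4, `CCCCCSc1nc(C(C)(C)C)ccc1CNC(=O)C(C)c1ccc(NS(C)(=O)=O)c(F)c1`, has not been measured. It differs from compound 3 by methyl in place of hydrogen on a saturated chain carbon, four bonds along the chain from a sulfur. This is the same kind of change as that from compound 1 to compound 2, but not the same: there the added methyl sat three bonds along the chain from an oxygen on an aromatic ring, here it sits four bonds along the chain from a sulfur. A single precedent, on a different core and chain length, is a thin basis. The step from compound 3 to compound 4 is expected to be a 1.3-fold lower number from compound 3 to compound 4 (0.12 log units; within the scatter), resting on the measured 1.9-fold lower number from compound 1 to compound 2 (0.28 log units; within the scatter). Compound 4 is therefore estimated at 2.4 nM, with a plausible range from 1 nM to 6 nM.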

Compound 4, inhibition constant: 3.1 nM
For compound 4 the middle estimate is 1.3-fold (0.11 log units) below the measured one; the measured number falls inside the stated range.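

In this assay, methyl in place of hydrogen on the sulfur-linked chain gave a 1.0-fold lower number from compound 3 to compound 4 (0.01 log units; within the scatter), and this step does not differ detectably from the same change on the oxygen-linked chain: the same change on two cores in this assay, a 1.9-fold lower number (0.28 log units; within the scatter) from compound 1 to compound 2 and a 1.0-fold lower number (0.01 log units; within the scatter) from compound 3 to compound 4, 1.8-fold (0.26 log units) apart, within the scatter of two such steps. The change therefore carried from one core to the other without a detectable difference, but both steps lie within the scatter, and one pair cannot show that it would do so on any other core or chain. Pentylsulfanyl in place of butoxy gave a 3.4-fold higher number from compound 2 to compound 4 (0.54 log units; beyond the scatter), beyond the scatter, whereas pentylsulfanyl in place of propoxy gave a 1.8-fold higher number from compound 1 to compound 4 (0.26 log units; within the scatter), within it, so the sulfur-linked compound 4 stands apart from only one of the two oxygen-linked compounds.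

The compounds shown leave open whether a pentyloxy group would give a number like that of compound 2 or one nearer that of compound 1. They also leave open how a hexylsulfanyl group or a chain carrying an amine would read in this assay.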